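Pyridazine-side amide variation: step from compound 3 to compound 4

The source may hold more compounds than are shown below. What is called first, only, known or untested is meant among the compounds shown, and "the series" means these compounds.

Compound 3 `Cc1ccccc1S(=O)(=O)N1CCN(c2ccc(C(=O)NCc3cncs3)nn2)CC1` stands lowest of the three measured in an ADME assay on microsomes from liver (Mus musculus), read by LC-MS, using NADPH, tested at 10 uM (on this read-out higher numbers stand for higher hepatic extraction and lower numbers for lower hepatic extraction), giving 0.77; compound 1 `Cc1ccccc1S(=O)(=O)N1CCN(c2ccc(C(=O)NCc3cccs3)nn2)CC1` gives 0.97 and compound 2 `Cc1ccccc1S(=O)(=O)N1CCN(c2cnc(C(=O)NCc3ccc(F)cc3)cn2)CC1` gives 0.95. Among the compounds with values here, the one step measured is a number 0.20 lower from compound 1 to compound 3 (beyond the scatter). Compound 4 `Cc1ccccc1S(=O)(=O)N1CCN(c2ccc(C(=O)NCc3ccc(F)cc3)nn2)CC1` differs from compound 3 by 4-fluorophenyl in place of 1,3-thiazol-5-yl on a saturated chain carbon bound to an amide-type nitrogen. Within the data shown here, no measured step covers this exact change, but compound 2 carries the same 4-fluorobenzyl group on a different core and gives 0.95, close to compound 1. The expectation is therefore a rise beyond the scatter, a number 0.16 higher from compound 3 to compound 4 (beyond the scatter). For compound 4 the estimate in this assay is 0.93, with a range from 0.85 to 0.99.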

Compound 4, hepatic extraction ratio: 0.7
Compound 4: middle estimate off by 0.23, on the high side; measured number outside the range, below it.
By their numbers in this assay, from the lowest: compounds 4 and 3 (each within the scatter of the next); then compounds 2 and 1 (each within the scatter of the next).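

In this assay, 4-fluorophenyl and 1,3-thiazol-5-yl are not separated at this position on the shared core, with a number 0.070 lower from compound 3 to compound 4 (within the scatter). Thiophen-2-yl alone stands apart from both, with a number 0.27 lower from compound 1 to compound 4 (beyond the scatter), so the earlier drop is not specific to the thiazole; the 4-fluorobenzyl value of compound 2, 0.95, on its different core, did not carry over. Nothing available here explains these values. Still open, from the compounds shown here alone, is whether a carboxylic acid or an amine on a saturated chain carbon bound to an amide-type nitrogen would bring the number lower than these aromatic rings do.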